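Amine-side variation at a chemokine receptor antagonist series

The compounds below may be only part of what the source reports. "The series", "measured", "known", "first", "only" and "open" are said of these compounds alone.

Compound 1 `c1ccc2c(c1)CN[C@@H](CN(CCCCNC1CCNCC1)[C@H]1CCCc3cccnc31)C2`: 63.4 nM
Compound 2 `CC1(C)CCC(NCCCCN(C[C@H]2Cc3ccccc3CN2)[C@H]2CCCc3cccnc32)CC1`: 77.6 nM
Compound 3 `NCc1ccccc1CN(C[C@H]1Cc2ccccc2CN1)[C@H]1CCCc2cccnc21`: 50.8 nM

In a functional assay on cells for antagonist activity at C-X-C chemokine receptor type 4 (Homo sapiens), read by fluorescence and calcium flux, with stated times of 25 min and 90 s (on this read-out higher numbers stand for weaker inhibition and lower numbers for stronger inhibition), compound 3 gives the lowest of the three numbers, yet its gaps to compound 1 and to compound 2 are both within the scatter, so the three compounds cannot be told apart on this read-out.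

Compound 4 `CC(C)(CN)CCN(C[C@H]1Cc2ccccc2CN1)[C@H]1CCCc2cccnc21` carries the change (2-(aminomethyl)-2-methylpropyl in place of 2-(aminomethyl)phenyl on a saturated chain carbon bound to an amine nitrogen). Among the compounds with values here, two measured steps bear on it, since both alter a group attached to the same saturated chain carbon bound to an amine nitrogen: a 1.2-fold higher number from compound 1 to compound 2 (0.09 log units; within the scatter) and a 1.2-fold lower number from compound 1 to compound 3 (0.10 log units; within the scatter). Neither moved the number beyond the scatter, even though the groups exchanged differ in size, in aromatic character and in ring count. On that basis no step beyond the scatter is expected in this assay for the move to the 2-(aminomethyl)-2-methylpropyl group, in either direction.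

Compound 4 is therefore estimated at 70 nM in this assay, with a range from 30 nM to 180 nM. The estimated step of a 1.4-fold higher number from compound 3 to compound 4 (0.14 log units; within the scatter) is expected to stay within the scatter.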

Compound 4, half-maximal inhibitory concentration: 69 nM
The estimate for compound 4 lay 1.0-fold (0.01 log units) above the measured number; the measured number falls inside the stated range.
By their numbers in this assay, from the lowest: compounds 3, 1, 4 and 2 (each within the scatter of the next).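

In this assay, the open-chain 2-(aminomethyl)-2-methylpropyl group, which has no ring, takes the place of the aromatic 2-(aminomethyl)phenyl group with a 1.4-fold higher number from compound 3 to compound 4 (0.13 log units; within the scatter), so an aromatic ring is not needed at this position to stay within the scatter. The ring-bearing side chains of the other two compounds are likewise exchanged for the open chain without a step beyond the scatter, with a 1.1-fold lower number from compound 2 to compound 4 (0.05 log units; within the scatter) and a 1.1-fold higher number from compound 1 to compound 4 (0.04 log units; within the scatter), so this position has so far tolerated every group shown. No measurement at hand accounts for this tolerance.

From the compounds shown here alone, all four side chains still carry an amine, so what a carboxylic acid, a hydroxyl group or a plain alkyl chain would do at this position remains open. The shared core stays the same throughout, so whether the same tolerance holds on a different core is also unresolved.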